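Trading a fluoro for a nitro on the urea-side ring

This account rests on a few compounds, and the source may have more. Where it says the series, first, only, none or still open, it means among the compounds named here.

Compound 1 `O=C(Nc1ccccc1F)N[C@H]1CC[C@H](Oc2ccc(F)cc2)CC1` is one of two urea compounds assessed in a functional assay on CRL2813 cells (Homo sapiens) for cytotoxicity, read by sulforhodamine B assay, with a stated time of 5 days; on this read-out higher numbers stand for weaker inhibition and lower numbers for stronger inhibition. Compound 1 gives 17500 nM, the highest of the two numbers; its nearest neighbour, compound 2 `O=C(Nc1cccc(C(F)(F)F)c1)N[C@H]1CC[C@H](Oc2ccccc2C(F)(F)F)CC1`, gives 1400 nM, a gap beyond the scatter. Compound 3 `O=C(Nc1ccccc1[N+](=O)[O-])N[C@H]1CC[C@H](Oc2ccc(F)cc2)CC1` has not yet been measured. It differs from compound 1 by nitro in place of fluoro on an aromatic carbon on an aromatic carbon of a six-membered aromatic ring of carbon only, ortho to a large group. Going by the values given here, with no comparable step among the measured compounds, only a small shift, if any beyond the scatter, is expected for a 1.5-fold lower number from compound 1 to compound 3 (0.16 log units; within the scatter). Compound 3 is thus estimated at 12000 nM, within 3000 nM to 50000 nM.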

Compound 3, half-maximal inhibitory concentration: 3500 nM
Compound 3: middle estimate off by 3.4-fold (0.54 log units), on the high side, within the range that was stated.
By their numbers in this assay, from the lowest: compound 2; then compound 3; then compound 1.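

In this assay, replacing 2-fluorophenyl with 2-nitrophenyl gives a 5.0-fold lower number from compound 1 to compound 3 (0.70 log units; beyond the scatter) and so lies beyond the scatter. Going by these compounds alone, this is the first change at a single place in this set, and it shows that the read-out responds to the group on this aromatic carbon, ortho to a large group. Nothing available here accounts for the step.

The compounds shown leave open whether an amine or a nitrile at this position would give a number nearer that of compound 1 or of compound 3. They also leave open whether the step holds when the other aromatic ring carries something other than fluoro.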